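The compounds below may be only part of what the source reports. "The series", "measured", "known", "first", "only" and "open" are said of these compounds alone.

Compound 1 `O=C(NCc1cccs1)N1C(=O)c2ccccc2S1(=O)=O`: > 166 h
Compound 2 `O=C(NCc1ccc(C(F)(F)F)cc1)N1C(=O)c2ccccc2S1(=O)=O`: > 166 h
Compound 3 `O=C(CCc1ccccc1)N1C(=O)c2ccccc2S1(=O)=O`: > 5.77 h

All three compounds share one core and differ only in the group hanging from it. In a physicochemical assay for pharmacokinetics (a lower number here means that the compound disappears faster, a higher number that the compound lasts longer), compound 1 gives > 166 h, which is a limit of the assay rather than a measured number. Compound 2 gives > 166 h, also a limit. Compound 3 gives > 5.77 h, again a limit. Within the data shown here, compound 1 therefore stands at the limit of > 166 h in this assay, at which 2 of the 3 values shown sit, and no pair of measured compounds differs in one place, so no measured step is known.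

Compound 4 `COc1ccccc1CNC(=O)N1C(=O)c2ccccc2S1(=O)=O` is the next one, made from compound 1 by 2-methoxyphenyl in place of thiophen-2-yl on a saturated chain carbon bound to an amide-type nitrogen. Since compound 1 sits at a limit, the step of a number no higher from compound 1 to compound 4 (the limit leaves the size open) is expected to stay within scatter. Compound 4 is thus expected to give 166 h, within 60 h to 500 h.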

Compound 4, half-life: > 166 h
Compound 4: a limit, no number; the forecaster's own chance of this, stated with the estimate: 80%; the middle value lies on the limit itself.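

The step from compound 1 to compound 4 cannot be read: both values are limits in this assay, not numbers. The compounds shown leave open how long any of them truly lasts, and whether thiophen-2-yl and 2-methoxyphenyl differ at all.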